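This account rests on a few compounds, and the source may have more. Where it says the series, first, only, none or still open, it means among the compounds named here.

Measured so far: compound 1 `Cc1c(OCCCCOc2ccc(Cl)c(C(=O)O)c2)ccc(C(=O)CC(C)(C)C)c1O` gives 130 nM in an assay for positive allosteric modulation of metabotropic glutamate receptor 3 (Rattus norvegicus); on this read-out higher numbers stand for an effect only at larger amounts of compound and lower numbers for an effect already at smaller amounts; compound 2 `Cc1ccc(OCCCCOc2ccc(C(=O)CC(C)(C)C)c(O)c2C)cc1C(=O)O` gives 309 nM.

Compound 2 stands with the higher of the two numbers. For the measured compounds named here, the only step measured, methyl in place of chloro, went a 2.4-fold higher number from compound 1 to compound 2 (0.38 log units; beyond the scatter). Compound 3 `COc1ccc(OCCCCOc2ccc(C(=O)CC(C)(C)C)c(O)c2C)cc1C(=O)O` carries the change (methoxy in place of methyl on an aromatic carbon), on the aromatic carbon ortho to a carboxy group. Going by the values given here, no measured step shows a methoxy at this place; the one step that touched it was modest. So the expected change from compound 2 to compound 3 is small, a 1.1-fold higher number from compound 2 to compound 3 (0.05 log units; within the scatter), within or barely beyond the scatter. Compound 3 is estimated at 350 nM, between 150 nM and 800 nM.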

Compound 3, half-maximal effective concentration: 490 nM
Compound 3: middle estimate off by 1.4-fold (0.15 log units), on the low side, and the stated range covers the measured number.
By their numbers in this assay, from the lowest: compound 1; then compounds 2 and 3 (each within the scatter of the next).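

Methoxy in place of methyl on this aromatic carbon, ortho to a carboxy group, gives a 1.6-fold higher number from compound 2 to compound 3 (0.20 log units; within the scatter) in this assay, so adding an oxygen and a hydrogen-bond acceptor here leaves the number within the usual scatter. Methoxy in place of chloro gives a 3.8-fold higher number from compound 1 to compound 3 (0.58 log units; beyond the scatter) and so, like methyl, leaves compound 1 with the lowest number of the three. Nothing measured here explains these differences. On these data alone, whether fluoro, a nitrile or an amine on this carbon would match chloro remains open, as does the effect of a longer ethoxy chain.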